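A few compounds are considered here, and "the series" means these few. Any claim that something is new, unique, unknown or untested is made for them only; others in the source may bear on it.

Working notes on the series. Going by the values given here, the three measured members share one core and differ only in the group on the amide-type nitrogen: compound 1 `O=C(Nc1ccccn1)c1c(O)c2cccnc2n(-c2ccccc2)c1=O`, compound 2 `CNC(=O)c1c(O)c2cccnc2n(-c2ccccc2)c1=O` and compound 3 `O=C(Nc1ccc([N+](=O)[O-])cc1)c1c(O)c2cccnc2n(-c2ccccc2)c1=O`. In a functional assay on the whole organism for inhibition, with Rattus norvegicus as the target, read by paw edema, at a dose of 100 mg/kg by the oral route (a higher number here means more inhibition at the dose given (going by the name of the read-out), a lower number less inhibition), compound 1 gives -13.5%, compound 2 gives 9.6% and compound 3 gives -7.6%. Among these three numbers compound 3 stands second highest; its nearest neighbour is compound 1, and the gap a number 5.9 percentage points higher from compound 1 to compound 3 (within the scatter) lies within the scatter, while the gap a number 17.2 percentage points lower from compound 2 to compound 3 (beyond the scatter) lies beyond it. The remaining measured step, a number 23.1 percentage points higher from compound 1 to compound 2 (beyond the scatter), also turns on the methyl member.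

Compound 4 `Cc1cccc(NC(=O)c2c(O)c3cccnc3n(-c3ccccc3)c2=O)c1` has not been measured. The change is 3-methylphenyl in place of 4-nitrophenyl on an amide-type nitrogen. Both measured steps that alter the group on the amide-type nitrogen bear on it. The one that keeps a six-membered aromatic ring on that nitrogen throughout, a number 5.9 percentage points higher from compound 1 to compound 3 (within the scatter), stayed within the scatter. The step that is beyond the scatter, a number 17.2 percentage points lower from compound 2 to compound 3 (beyond the scatter), exchanges methyl for a ring, which compound 4 does not do. On this basis the expected step in this assay is a number 2.6 percentage points higher from compound 3 to compound 4 (within the scatter), nothing beyond the scatter. Compound 4 is therefore estimated at -5% in this assay, with a range from -25% to 15%.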

Compound 4, a percentage reported as inhibition, in the whole organism at one dose (the size of the read-out at that dose, not a potency): 14.2%
Estimate against measurement, compound 4: 19.2 percentage points below, and the stated range covers the measured number.
By their numbers in this assay, from the lowest: compounds 1 and 3 (each within the scatter of the next); then compounds 2 and 4 (each within the scatter of the next).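

The step of a number 21.8 percentage points higher from compound 3 to compound 4 (beyond the scatter) shows that, in this assay, exchanging one six-membered aromatic ring for another on the amide-type nitrogen can move the read-out beyond the scatter, which the earlier ring-for-ring step from pyridin-2-yl to 4-nitrophenyl did not show. A ring at this position therefore does not by itself go with the lower numbers: the step of a number 4.6 percentage points higher from compound 2 to compound 4 (within the scatter) stays within the scatter, whereas the step of a number 27.7 percentage points higher from compound 1 to compound 4 (beyond the scatter) lies beyond it, so 3-methylphenyl reads with methyl and apart from both pyridin-2-yl and 4-nitrophenyl. Nothing measured here gives a reason for these steps.

Since 4-nitrophenyl and 3-methylphenyl differ in both the group carried and where it sits on the ring, the compounds shown do not tell whether the loss of nitro, the gain of methyl or the change of place accounts for the step. As far as these compounds go, how an unsubstituted phenyl, 4-methylphenyl or 3-nitrophenyl group would read on the same nitrogen remains open, as does a longer chain such as butyl in place of methyl.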